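The source may report more compounds than this note shows. Statements on the series, on what has been measured and on what is new or still open speak of the compounds shown alone.

Measured compounds in a physicochemical assay for lipophilicity, read by HPLC; on this read-out lower numbers stand for lower lipophilicity and higher numbers for higher lipophilicity: compound 1 `Cc1cccc(NC(=O)c2ccc3cccc(O)c3n2)c1` gives 2.5; compound 2 `Cc1ccc(NC(=O)c2ccc3cccc(O)c3n2)cc1` gives 2.5; compound 3 `O=C(Nc1ccccc1Br)c1ccc2cccc(O)c2n1` gives 2.5.

Compound 3 stands level with compounds 1 and 2 at the digits shown. The steps among them, no change at the digits printed from compound 1 to compound 2 (within the scatter), no change at the digits printed from compound 1 to compound 3 (within the scatter) and no change at the digits printed from compound 2 to compound 3 (within the scatter), all stay within the scatter, whether the amide-type nitrogen carries 3-methylphenyl, 4-methylphenyl or 2-bromophenyl.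

Compound 4 `O=C(Nc1ccc(Br)cc1)c1ccc2cccc(O)c2n1` differs from compound 3 by 4-bromophenyl in place of 2-bromophenyl on an amide-type nitrogen. The step from compound 1 to compound 2 bears on it most closely, a move of a methyl between ring positions, and it showed no change in this assay. The step from compound 3 to compound 4 is therefore expected to be no change at the digits printed from compound 3 to compound 4 (within the scatter), none beyond the scatter. Compound 4 is estimated at 2.5, in the range 2.2 to 2.9.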

Compound 4, partition coefficient: 2.5
The estimate for compound 4 equals the measured number at the digits printed, and the stated range covers the measured number.
By their numbers in this assay, from the lowest: compounds 1, 2, 3 and 4 (each within the scatter of the next).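

In this assay, 4-bromophenyl in place of 2-bromophenyl on the amide-type nitrogen gives no change at the digits printed from compound 3 to compound 4 (within the scatter), so the flat result seen for the two methylphenyl isomers also holds for a pair of bromophenyl isomers. Bromo in place of methyl on an aromatic carbon, a single change not read before, gives no change at the digits printed from compound 2 to compound 4 (within the scatter), and 4-bromophenyl in place of 3-methylphenyl gives no change at the digits printed from compound 1 to compound 4 (within the scatter). No measured evidence on hand accounts for these flat steps.

Still open, from the compounds shown here alone, is how an amine or a carboxylic acid on the phenyl ring would read. Going by these compounds, a longer alkyl chain in place of the phenyl ring on the amide-type nitrogen is equally open.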